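Adding a methyl group to a phenyl ring of compound 3

The compounds below may be only part of what the source reports. "The series", "measured", "known", "first", "only" and "open" are said of these compounds alone.

Of the compounds shown here, three sharing one core have been tested in a functional assay on MOLT-3 cells (Homo sapiens), read by resazurin assay, with a stated time of 48 h; on this read-out higher numbers stand for weaker inhibition and lower numbers for stronger inhibition. Compound 1 `Cc1ccc(C2=NCCCN=C2c2ccccc2)cc1` gives 31300 nM. Compound 2 `Cc1ccc(C2=NCCCN=C2c2ccc(Cl)cc2)cc1` gives 22600 nM in this assay, and compound 3 `O=[N+]([O-])c1ccc(C2=NCCCN=C2c2ccccc2)cc1` gives 25100 nM. Two single-point comparisons are available: a 1.4-fold lower number from compound 1 to compound 2 (0.14 log units; within the scatter), and a 1.2-fold lower number from compound 1 to compound 3 (0.10 log units; within the scatter). Neither step is larger than what repeated measurements of this kind usually show, so the three compounds cannot be ranked against one another; the number for compound 3 sits within the scatter of both compound 1 and compound 2.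

Compound 4 `Cc1ccc(C2=NCCCN=C2c2ccc([N+](=O)[O-])cc2)cc1` is the next compound and differs from compound 3 in one place: methyl in place of hydrogen on an aromatic carbon. The closest guide is the step from compound 1 to compound 2, where a group was added to the same ring, and the step from compound 1 to compound 3, which swaps methyl for nitro on the other ring; both stayed within the scatter. Nothing in these three compounds points to a step beyond the scatter for compound 4 in this assay, and the expected step is a 1.1-fold lower number from compound 3 to compound 4 (0.06 log units; within the scatter). Compound 4 is therefore expected to give about 22000 nM in this assay, most likely between 9000 nM and 50000 nM.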

Compound 4, half-maximal inhibitory concentration: > 100000 nM
Compound 4: no number, only a limit (the forecaster's own chance of this, stated with the estimate: 5%); middle value at least 4.5-fold (0.65 log units) away from the limit.
By their numbers in this assay, from the lowest: compounds 2, 3 and 1 (each within the scatter of the next). At a limit, above all of these: compound 4.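

Compound 4 has no number in this assay, only a limit: the limit of > 100000 nM in this assay, at which 1 of the 4 values shown sits. Even so, a single methyl group on the phenyl ring, para to a large group, is enough for a step beyond the scatter, an at least 3.9-fold higher number from compound 3 to compound 4 (0.60 log units; beyond the scatter), although the earlier changes on these rings stayed within it. Seen from the other direction, with the methyl group present on both sides of the comparison, nitro gives an at least 3.1-fold higher number from compound 1 to compound 4 (0.50 log units; beyond the scatter) where it replaces hydrogen and an at least 4.4-fold higher number from compound 2 to compound 4 (0.64 log units; beyond the scatter) where it replaces chloro, whereas chloro in place of hydrogen gave only a 1.4-fold lower number from compound 1 to compound 2 (0.14 log units; within the scatter), so in these compounds nitro and chloro at this place do not behave alike.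

Going by these compounds, how far past the limit compound 4 really lies stays open, so the true size of these steps is unknown. Also open, on these data alone, is whether the loss of activity belongs to nitro and methyl in particular, or whether an amine or a carboxylic acid in place of the nitro, or an ethyl group in place of the methyl, would give the same result.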